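The source may report more compounds than this note shows. Statements on the series, on what has been measured and on what is new or still open speak of the compounds shown alone.

In an ADME assay on J774 cells (Mus musculus) for cytotoxicity (a lower number here means that less compound is needed, a higher number that more compound is needed for the effect), compound 1 `Cc1[nH]c2ccccc2c(=O)c1Cc1ccccc1` gives > 40100 nM, which is a limit and not a number. Compound 2 `COc1ccc2[nH]c(C)c(Cc3ccccc3)c(=O)c2c1` gives > 23700 nM, also a limit, so it has no measured number in this assay and cannot be ranked against compound 1. Among the compounds with values here, the only measured step, a step that the two limits leave unreadable from compound 1 to compound 2, has no readable size.

Compound 3 `Cc1[nH]c2ccc(Cl)cc2c(=O)c1Cc1ccccc1` differs from compound 2 by chloro in place of methoxy on an aromatic carbon. With a step that the two limits leave unreadable from compound 1 to compound 2 unreadable, the series offers no measured size to carry over to this change. No step beyond the scatter is therefore expected in this assay, in either direction. The estimated step is a step that the limit leaves unreadable from compound 2 to compound 3. For compound 3 the expected value is 30000 nM, with an estimated range of 10000 nM to 60000 nM. A report as a limit alone is also expected to be likely.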

Compound 3, half-maximal effective concentration: > 35200 nM
Compound 3 was reported as a limit; the forecaster's own chance of this, stated with the estimate: 70%; middle value at least 1.1-fold (0.06 log units) from the limit.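

In this assay compound 3 gives > 35200 nM, which is a limit. Within the data shown here, compound 1 and compound 2 are limits too, so no step among the three can be read. The compounds shown leave open whether methoxy or chloro in place of hydrogen on an aromatic carbon shifts the concentration needed for the effect in this assay.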